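Removing a Chloro Group from a Weak Sulfurtransferase Inhibitor

The source may report more compounds than this note shows. Statements on the series, on what has been measured and on what is new or still open speak of the compounds shown alone.

Two compounds sharing the same core have been examined in an assay on isolated protein for inhibition of thiosulfate sulfurtransferase (Homo sapiens), with a stated time of 60 min, in the absence of a further agent; a higher number here means a weaker inhibitor, a lower number a stronger inhibitor. Compound 1 `O=C(Nc1ccc(Sc2nc3ccccc3s2)cc1)c1ccccc1` gives in this assay only a limit, > 100000 nM. Compound 2 `O=C(Nc1ccc(Sc2nc3ccccc3s2)c(Cl)c1)c1cc(Br)cc(Br)c1O` likewise gives in this assay only a limit, > 100000 nM. Compound 2 therefore stands at the edge of what this assay can report, and since both values sit at the limit of > 100000 nM in this assay, at which 2 of the 2 values shown sit, neither compound can be placed above or below the other. Compound 3 `O=C(Nc1ccc(Sc2nc3ccccc3s2)cc1)c1cc(Br)cc(Br)c1O` is the next compound; it differs from compound 2 by hydrogen in place of chloro on an aromatic carbon. Going by the values given here, no measured step exists that shows how such a change affects this assay, so the expected step from compound 2 to compound 3 is estimated as a step that the limit leaves unreadable from compound 2 to compound 3, which is no change beyond the usual scatter. Compound 3 is accordingly expected to show about 150000 nM in this assay, within a range from 50000 nM to 500000 nM, most probably again as a limit rather than a number.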

Compound 3, half-maximal inhibitory concentration: > 100000 nM
Compound 3: no number, only a limit; the forecaster's own chance of this, stated with the estimate: 85%; the middle value is on the limit's open side.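

No step can be read from compound 2 to compound 3 or from compound 1 to compound 3, because all three compounds end at the same limit: the limit of > 100000 nM in this assay, at which 3 of the 3 values shown sit. The compounds shown leave open whether the chloro or the 3,5-dibromo-2-hydroxyphenyl group changes inhibition at all.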